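Swapping the Urea Aryl Group on Compound 2

The source may hold more compounds than are shown below. What is called first, only, known or untested is meant among the compounds shown, and "the series" means these compounds.

Compound 2 `COc1cc2ncnc(NCc3cccc(NC(=O)Nc4cccc(C)c4)c3)c2cc1OC` was tested in a functional assay on MGC-803 cells (Homo sapiens) for antiproliferative activity, read by MTT assay (on this read-out lower numbers stand for stronger inhibition and higher numbers for weaker inhibition), and gave 44600 nM. For the measured compounds named here, of the two numbers known so far, compound 2 stands highest; its nearest neighbour, compound 1 `Cc1cccc(NC(=O)Nc2cccc(CNc3ncnc4ccccc34)c2)c1`, gave 30200 nM in this assay, and that gap lies within the scatter of repeated measurements, so the two cannot be ordered against each other. Compound 3 `COc1cc2ncnc(NCc3cccc(NC(=O)Nc4ccccc4Cl)c3)c2cc1OC` has not yet been measured. It differs from compound 2 by 2-chlorophenyl in place of 3-methylphenyl on an amide-type nitrogen. Going by the values given here, no measured pair in this set shows what such an exchange does, so there is no basis for expecting a step beyond the scatter in either direction. Because compound 2 gave 44600 nM, compound 3 is expected at 40000 nM, within a range from 15000 nM to 100000 nM. That estimate amounts to a step of a 1.1-fold lower number from compound 2 to compound 3 (0.05 log units; within the scatter), expected to stay within the scatter.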

Compound 3, half-maximal inhibitory concentration: 30200 nM
Compound 3: middle estimate off by 1.3-fold (0.12 log units), on the high side, and the stated range covers the measured number.
By their numbers in this assay, from the lowest: compounds 1, 3 and 2 (each within the scatter of the next).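

In this assay the exchange of 3-methylphenyl for 2-chlorophenyl on the amide-type nitrogen gives a 1.5-fold lower number from compound 2 to compound 3 (0.17 log units; within the scatter) and provides the first step read at this position. Within this pair, replacing a methyl-bearing phenyl with a chlorine-bearing phenyl leaves compound 2 and compound 3 unseparated by this read-out. Nothing measured here offers an explanation for this result.

The compounds shown leave open whether a group without an aromatic ring, such as cyclohexyl, or a phenyl ring carrying an amine or a carboxylic acid, would move the number beyond the scatter when placed on this amide-type nitrogen. They also leave open whether 2-chlorophenyl in place of 3-methylphenyl would give a similar step on the core of compound 1.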